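A few compounds are considered here, and "the series" means these few. Any claim that something is new, unique, unknown or untested is made for them only; others in the source may bear on it.

Working notes on the series, read in a functional assay on A549 cells (Homo sapiens) for antiproliferative activity, with a stated time of 5 days; on this read-out lower numbers stand for stronger inhibition and higher numbers for weaker inhibition. Among the measured compounds shown here, compound 2 (`Cc1ccc(-n2nc(-c3ccc4ccccc4c3)nc2N2C(=O)COC23C=CC(=O)C=C3)cc1`) gives 110 nM, the lowest of the three numbers so far, and its gaps to the other two lie beyond the scatter. Compound 3 (`O=C1C=CC2(C=C1)OCC(=O)N2c1nc(-c2ccc3ccccc3c2)nn1-c1ccc2ccccc2c1`) gives 250 nM, and compound 1 (`CC1OC2(C=CC(=O)C=C2)N(c2nc(-c3ccc4ccccc4c3)nn2-c2ccc3ccccc3c2)C1=O`) gives 300 nM.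

The next compound is compound 4 (`Cc1ccc(-n2nc(-c3ccc4ccccc4c3)nc2N2C(=O)C(C)OC23C=CC(=O)C=C3)cc1`). Its change from compound 2 is methyl in place of hydrogen on a saturated ring carbon.

The closest evidence is a single pair carrying naphthalen-2-yl on the aromatic nitrogen, where the same exchange runs the other way: a 1.2-fold lower number from compound 1 to compound 3 (0.08 log units; within the scatter). Read in reverse, that step gives no sign that adding the methyl moves the number. It cannot be assumed to carry over unchanged, since the group on the aromatic nitrogen does register in this assay: a 2.3-fold higher number from compound 2 to compound 3 (0.36 log units; beyond the scatter). For the measured compounds named here, no pair with 4-methylphenyl on that nitrogen has yet tested the methyl. No step beyond the scatter is therefore expected, with at most a slight lean towards a higher number. The expected step is a 1.2-fold higher number from compound 2 to compound 4 (0.07 log units; within the scatter), which would stay within the scatter. Compound 4 is estimated at 130 nM, with an expected range of 65 nM to 260 nM.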

Compound 4, half-maximal inhibitory concentration: 1210 nM
Compound 4: the middle estimate sits 9.3-fold (0.97 log units) below what was measured; measured number above the stated range.
By their numbers in this assay, from the lowest: compound 2; then compounds 3 and 1 (each within the scatter of the next); then compound 4.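

In this assay, the methyl on the saturated ring carbon next to the ring oxygen is not a neutral change. With 4-methylphenyl on the aromatic nitrogen it gives an 11-fold higher number from compound 2 to compound 4 (1.04 log units; beyond the scatter), so its effect depends on the group on that nitrogen, as the same exchange on the two cores shows: the same change on two cores in this assay, a 1.2-fold lower number (0.08 log units; within the scatter) from compound 1 to compound 3 and an 11-fold lower number (1.04 log units; beyond the scatter) from compound 4 to compound 2, 9.2-fold (0.96 log units) apart, beyond the scatter of two such steps

The dependence also runs the other way, since the 4-methylphenyl core holds the lowest number with hydrogen on the ring carbon but sits higher once the methyl is present, giving a 4.0-fold higher number from compound 1 to compound 4 (0.61 log units; beyond the scatter), and the exchange on the aromatic nitrogen changes direction: the same change on two cores in this assay, a 2.3-fold higher number (0.36 log units; beyond the scatter) from compound 2 to compound 3 and a 4.0-fold lower number (0.61 log units; beyond the scatter) from compound 4 to compound 1, 9.2-fold (0.96 log units) apart, beyond the scatter of two such steps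

Within these four compounds the two positions therefore cannot be read as independent, and the lead of compound 2 holds only with hydrogen on the ring carbon.

As far as these compounds go, only hydrogen and methyl are seen on this carbon, so it remains open whether an ethyl or a hydroxymethyl there would follow the methyl on either core. Among the compounds shown here, only two groups are seen on the aromatic nitrogen, so it also remains open whether a plain phenyl or a 4-methoxyphenyl would respond to the methyl like 4-methylphenyl or like naphthalen-2-yl.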